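This account rests on a few compounds, and the source may have more. Where it says the series, first, only, none or still open, it means among the compounds named here.

Measured compounds:
- compound 1, `O=C(Nc1ccc(Cl)c(-c2nnc3c(Cl)cccn23)c1)c1cccc(Cl)c1`: 66100 nM
- compound 2, `O=C(Nc1ccc(Cl)c(-c2nnc3c(Cl)cccn23)c1)c1c(F)cccc1Cl`: > 100000 nM
- compound 3, `CS(=O)(=O)c1cccc(C(=O)Nc2ccc(Cl)c(-c3nnc4c(Cl)cccn34)c2)c1`: > 100000 nM

All three were tested in a functional assay on MDA-MB-231 cells (Homo sapiens) for antiproliferative activity, read by MTT assay, with stated times of 72 h and 4 h; on this read-out higher numbers stand for weaker inhibition and lower numbers for stronger inhibition. For compound 2 the value is a limit of the assay, not a number. For compound 3 the value is likewise a limit, the one at which (the limit of > 100000 nM in this assay, at which 2 of the 3 values shown sit), so compound 3 stands at the edge of what this assay can read, with only compound 1 giving a real number.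

Compound 4 , `O=C(Nc1ccc(Cl)c(-c2nnc3c(Cl)cccn23)c1)c1cccnc1Cl`, differs from compound 3 by 2-chloropyridin-3-yl in place of 3-(methylsulfonyl)phenyl on a carbonyl carbon. For the measured compounds named here, two measured steps touch this position. The step of an at least 1.5-fold higher number from compound 1 to compound 3 (0.17 log units; that floor lies within the scatter) shows the methylsulfonyl group costing at least a little. The step that the two limits leave unreadable from compound 2 to compound 3 cannot be sized, since both ends are limits. The entering group resembles the 3-chlorophenyl of compound 1 more than the departing one, and compound 1 gives 66100 nM.

Compound 4 is therefore expected at 70000 nM, with a range of 20000 nM to 200000 nM. That estimate implies an expected step of an at least 1.4-fold lower number from compound 3 to compound 4 (0.15 log units; that floor lies within the scatter), though with compound 3 at a limit its true size stays unreadable.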

Compound 4, half-maximal inhibitory concentration: 89700 nM
For compound 4 the middle estimate is 1.3-fold (0.11 log units) below the measured one; low and high end bracket the measured number.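

The change gives this position a second real number in this assay, and it shows a 1.4-fold higher number from compound 1 to compound 4 (0.13 log units; within the scatter), so 2-chloropyridin-3-yl and 3-chlorophenyl on this carbonyl carbon cannot be told apart here. Against the two compounds held at a limit, only floors can be read, an at least 1.1-fold lower number from compound 3 to compound 4 (0.04 log units; that floor lies within the scatter) and an at least 1.1-fold lower number from compound 2 to compound 4 (0.04 log units; that floor lies within the scatter), so the true size of these steps stays unknown: the limit of > 100000 nM in this assay, at which 2 of the 4 values shown sit A ring with a hetero atom on this carbonyl carbon thus gives a readable number, as the carbon-only ring of compound 1 does, while the carbon-only rings of compound 2 and compound 3 do not.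

As far as these compounds go, how an amine or a longer chain would read on this carbonyl carbon stays open. So does whether the chlorine or the ring nitrogen of 2-chloropyridin-3-yl matters, since no compound shown separates the two.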